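Chloro in Place of Trifluoromethyl: Compound 1 to Compound 3

This account rests on a few compounds, and the source may have more. Where it says the series, first, only, none or still open, it means among the compounds named here.

Measured compounds:
- compound 1, `O=C(CN1CCN(c2nnc(Cc3ccccc3)c3ccccc23)CC1)Nc1ccc(F)c(C(F)(F)F)c1`: 760 nM
- compound 2, `Cc1cccc(Cl)c1NC(=O)CN1CCN(c2nnc(Cc3ccncc3)c3ccccc23)CC1`: 2670 nM

In a functional assay on MDA-MB-231 cells (Homo sapiens) for cytotoxicity, read by MTT assay, with a stated time of 72 h (a higher number here means a weaker inhibitor, a lower number a stronger inhibitor), compound 1 gives 760 nM, the lower of the two numbers shown. Compound 2 gives 2670 nM, a higher number, and the gap between the two lies beyond the usual scatter of repeated measurements; compound 2 also differs from compound 1 in more than one place, so nothing is said here about any single change between them.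

Compound 3, `O=C(CN1CCN(c2nnc(Cc3ccccc3)c3ccccc23)CC1)Nc1ccc(F)c(Cl)c1`, has not been measured. It is compound 1 with one change: chloro in place of trifluoromethyl on an aromatic carbon. For the measured compounds named here, no pair of measured compounds differs in one place, so no measured step guides this one. Without such a guide, the change is expected to shift this assay only slightly, with a step from a 1.4-fold higher number from compound 1 to compound 3 (0.16 log units; within the scatter) that stays close to the scatter. Compound 3 is therefore estimated at 1100 nM, within a range from 400 nM to 3000 nM.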

Compound 3, half-maximal inhibitory concentration: 7360 nM
Estimate against measurement, compound 3: 6.7-fold (0.83 log units) below; the measured number lies above the stated range.
By their numbers in this assay, from the lowest: compound 1; then compound 2; then compound 3.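

In this assay, for the compounds shown here, the change from trifluoromethyl to chloro on the aromatic carbon ortho to a fluoro group gives a 9.7-fold higher number from compound 1 to compound 3 (0.99 log units; beyond the scatter) and is the first single-place comparison in this set. It shows that this position is not indifferent to the group it carries: with everything else held constant, the single-atom chloro gives a clearly weaker result in these cells than the four-atom trifluoromethyl. No measurement available here accounts for the size of this step.

Going by these compounds, only these two groups have been compared at this position, so it remains open whether a methyl group, a nitrile or a methoxy group would stay close to compound 1 or fall closer to compound 3. On these data alone, it is also open whether the same exchange would have a similar effect on a compound with a different remaining structure.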